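An ethynyl added to the glycerol ether arm of compound 1

This account rests on a few compounds, and the source may have more. Where it says the series, first, only, none or still open, it means among the compounds named here.

Compound 1, `CCCCCCCC/C=C\CCCCCCCC(=O)OC[C@@H](COC)OP(=O)(O)OC[C@H](N)C(=O)O`: 12.9%
Compound 2, `CCCCCCCC/C=C\CCCCCCCC(=O)OC[C@H](COC)OP(=O)(O)OC[C@H](N)C(=O)O`: 7.5%

In an assay on HEK293 cells for agonist activity at probable G-protein coupled receptor 34 (Mus musculus), with a stated time of 1 h (a lower number here means a smaller maximal response, a higher number a larger maximal response), compound 1 gives the highest of the two numbers; its nearest neighbour is compound 2, with a number 5.4 percentage points lower from compound 1 to compound 2 (within the scatter). That step changes only a stereocentre, and the fact that one of compounds 1 and 2 is drawn with a defined configuration and the other without, at the place where they differ is all that is known about it.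

Compound 3, `C#CCOC[C@H](COC(=O)CCCCCCC/C=C\CCCCCCCC)OP(=O)(O)OC[C@H](N)C(=O)O`, differs from compound 1 by ethynyl in place of hydrogen on a saturated chain carbon bound to an oxygen on a saturated carbon. Going by the values given here, no measured step bears on this change, so the direction is open and no step beyond the scatter is assumed. Compound 3 is expected to show a number 0.1 percentage points higher from compound 1 to compound 3 (within the scatter). Compound 3 is therefore estimated at 13%, with a range from 3% to 35%.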

Compound 3, largest response reached (Emax), in percent of the reference or control that the assay uses: 12.6%
Compound 3: middle estimate off by 0.4 percentage points, on the high side, and the stated range covers the measured number.
By their numbers in this assay, from the lowest: compounds 2, 3 and 1 (each within the scatter of the next).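

Compounds 1 and 2 differ only at a stereocentre, so they said nothing about the end of the ether arm. Here, in this assay, ethynyl in place of hydrogen on this saturated chain carbon, turning methoxy into propargyloxy, gives a number 0.3 percentage points lower from compound 1 to compound 3 (within the scatter), so this added group leaves the maximal response indistinguishable from that of compound 1. The information available offers no explanation for this result. Still open, from the compounds shown here alone, is whether an amine, a carboxylic acid or a longer chain at this position would shift the response beyond the scatter. Also open, going by these compounds, is how the propargyloxy arm behaves with the stereocentre configuration of compound 2.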